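Cytotoxicity notes: chloro to hydrogen from compound 3

The compounds below may be only part of what the source reports. "The series", "measured", "known", "first", "only" and "open" are said of these compounds alone.

The series shares one core, seen in compound 1 `COc1ccc(Br)cc1C(=O)Nc1ccc(Sc2nc3ccccc3s2)cc1`. In an ADME assay on HEK293 cells (Homo sapiens) for cytotoxicity, read by reporter gene assay and resazurin assay, with a stated time of 48 h (a higher number here means that more compound is tolerated, a lower number that less compound is tolerated), compound 1 gives > 100000 nM, which is a limit of the assay and not a number (the limit of > 100000 nM in this assay, at which 1 of the 3 values shown sits). Compound 2 `O=C(Nc1ccc(Sc2nc3ccccc3s2)cc1)c1cccc(Br)c1` gives 74000 nM in this assay, and compound 3 `O=C(Nc1ccc(Sc2nc3ccccc3s2)c(Cl)c1)c1cccc(Br)c1O` gives 64000 nM. Compound 3 holds the lowest of the two numbers shown; its nearest neighbour is compound 2, and the two lie within the scatter of each other. Among the measured compounds shown here, the only step measured between neighbours is an at least 1.3-fold lower number from compound 1 to compound 2 (0.13 log units; that floor lies within the scatter), whose floor lies within the scatter. Compound 4 `O=C(Nc1ccc(Sc2nc3ccccc3s2)cc1)c1cccc(Br)c1O` differs from compound 3 by hydrogen in place of chloro on an aromatic carbon. For the measured compounds named here, no measured step removes a chloro, so the one measured step gives no direct guide, and the pair of numbers for compound 2 and compound 3 shows nothing beyond the scatter either. For compound 4 a step of a 1.1-fold higher number from compound 3 to compound 4 (0.04 log units; within the scatter) is therefore expected, none beyond the scatter. Compound 4 is estimated at 70000 nM, within 30000 nM to 150000 nM.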

Compound 4, half-maximal cytotoxic concentration: 71000 nM
Beside the measured number, compound 4's estimate is 1.0-fold (0.01 log units) below it; measured number inside the range.
By their numbers in this assay, from the lowest: compounds 3, 4 and 2 (each within the scatter of the next). At a limit, above all of these: compound 1.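

In this assay, hydrogen in place of chloro on the aromatic carbon gives a 1.1-fold higher number from compound 3 to compound 4 (0.05 log units; within the scatter), so the series now has a direct reading at this position and it shows no step beyond the scatter. Hydroxy in place of hydrogen, read on its own for the first time, gives a 1.0-fold lower number from compound 2 to compound 4 (0.02 log units; within the scatter), again within the scatter. Compound 1 stands at a limit of the assay and not a number, so an at least 1.4-fold lower number from compound 1 to compound 4 (0.14 log units; that floor lies within the scatter) sets only a floor and no size for the exchange of aryl groups: the limit of > 100000 nM in this assay, at which 1 of the 4 values shown sits.

On these data alone, whether an amine or a carboxylic acid in place of the chloro would give a step beyond the scatter stays open. As far as these compounds go, the separate contributions of the methoxy and the hydroxy to the exchange of aryl groups also stay open.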